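Swapping a Fluorophenyl for a Methoxyphenyl Styryl Group

A few compounds are considered here, and "the series" means these few. Any claim that something is new, unique, unknown or untested is made for them only; others in the source may bear on it.

Compound 1 `COc1cc2nc(/C=C/c3ccccc3F)nc(N3CCC(CCNS(N)(=O)=O)CC3)c2cc1OC`: 78%
Compound 2 `COc1ccccc1/C=C/c1nc(N2CCC(CCNS(N)(=O)=O)CC2)c2cc(OC)c(OC)cc2n1`: 74%

Of the two compounds measured in an assay on cells for inhibition of Ectonucleotide pyrophosphatase/phosphodiesterase family member 1 (Homo sapiens), with a stated time of 60 min, tested at 1 uM (a higher number here means more inhibition at the concentration tested (going by the name of the read-out), a lower number less inhibition), compound 1 gives the highest number; compound 2 lies a number 4 percentage points lower from compound 1 to compound 2 (within the scatter) away, within the scatter. Compound 3 `COc1ccc(/C=C/c2nc(N3CCC(CCNS(N)(=O)=O)CC3)c3cc(OC)c(OC)cc3n2)cc1` has not been measured. It differs from compound 1 by 4-methoxyphenyl in place of 2-fluorophenyl on a double-bonded chain carbon bound to a double-bonded chain carbon. For the measured compounds named here, the only measured step that bears on this, a number 4 percentage points lower from compound 1 to compound 2 (within the scatter), also exchanges fluoro for methoxy and stays within the scatter, so no step beyond the scatter is expected here either. Compound 3 is therefore expected to shift by a number 4 percentage points lower from compound 1 to compound 3 (within the scatter), giving an estimate of 74% with a range from 56% to 88%.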

Compound 3, a percentage reported as inhibition, at one concentration (the size of the read-out at that concentration, not a potency): 66%
Beside the measured number, compound 3's estimate is 8 percentage points above it, and the stated range covers the measured number.
By their numbers in this assay, from the lowest: compounds 3, 2 and 1 (each within the scatter of the next, the first and the last beyond it).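

In this assay, for the compounds shown here, this position proves sensitive to the change: replacing 2-fluorophenyl with 4-methoxyphenyl gives the first step here beyond the scatter, though a modest one (a number 12 percentage points lower from compound 1 to compound 3 (beyond the scatter)). Exchanging 2-methoxyphenyl for 4-methoxyphenyl gives a step that stays within the scatter (a number 8 percentage points lower from compound 2 to compound 3 (within the scatter)), so that exchange alone shows no clear effect. Nothing shown here explains the lower number. The compounds leave open whether the fluoro-to-methoxy exchange or the new ring position matters more, and 4-fluorophenyl would separate the two. Going by these compounds, how an amine or a carboxylic acid would fare on this ring also remains open.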